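The source may hold more compounds than are shown below. What is called first, only, known or untested is meant among the compounds shown, and "the series" means these compounds.

Going by the values given here, in a functional assay on KB 3-1 cells (Homo sapiens) for antiproliferative activity, read by MTT assay (a higher number here means a weaker inhibitor, a lower number a stronger inhibitor), compound 2 `C=CC[C@H]1C(=O)C[C@@H]2[C@@H](C)[C@H](O[Si](c3ccccc3)(c3ccccc3)C(C)(C)C)C[C@@H]21` gives 6900 nM, the lowest number of the three measured so far. Compound 1 `C[C@@H]1[C@H]2CC(=O)[C@H](C)[C@H]2C[C@H]1O[Si](c1ccccc1)(c1ccccc1)C(C)(C)C` gives 15200 nM and compound 3 `C=CC[C@@H]1[C@H]2CC(=O)[C@H](C)[C@H]2C[C@H]1O[Si](c1ccccc1)(c1ccccc1)C(C)(C)C` gives 16000 nM, and these two lie within the scatter of each other.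

Compound 4 `CC(C)=CC[C@H]1C(=O)C[C@@H]2[C@@H](C)[C@H](O[Si](c3ccccc3)(c3ccccc3)C(C)(C)C)C[C@@H]21` has not yet been measured. It differs from compound 2 by 2-methylprop-1-en-1-yl in place of vinyl on a saturated chain carbon bound to a saturated ring carbon, which, cut one bond further out, reads allyl to 3-methylbut-2-en-1-yl.

Among the compounds with values here, no measured step makes this exact change, but two bear on it. Vinyl in place of hydrogen gives a 2.2-fold lower number from compound 1 to compound 2 (0.34 log units; beyond the scatter), a modest step beyond the scatter. The same change, described in the same words but leading to a different structure, gives a 1.1-fold higher number from compound 1 to compound 3 (0.02 log units; within the scatter), which stays within the scatter. Within the data shown here, these steps are small or absent, and the series holds no compound with a branched chain end.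

A step beyond the scatter is therefore not expected, and no direction is favoured. The expected step is a 1.1-fold lower number from compound 2 to compound 4 (0.03 log units; within the scatter). In this assay, the estimated value for compound 4 is 6500 nM, with an expected range of 2800 nM to 15000 nM.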

Compound 4, half-maximal inhibitory concentration: 28200 nM
Compound 4: middle estimate off by 4.3-fold (0.64 log units), on the low side, and the stated range ends below it.
By their numbers in this assay, from the lowest: compound 2; then compounds 1, 3 and 4 (each within the scatter of the next).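

In this assay, this saturated chain carbon bound to a saturated ring carbon proves sensitive to the end of the chain: 2-methylprop-1-en-1-yl in place of vinyl gives a clear weakening (a 4.1-fold higher number from compound 2 to compound 4 (0.61 log units; beyond the scatter)), opposite in direction to the earlier step of vinyl in place of hydrogen (a 2.2-fold lower number from compound 1 to compound 2 (0.34 log units; beyond the scatter)). Set against hydrogen, 2-methylprop-1-en-1-yl shows no change beyond the scatter (a 1.9-fold higher number from compound 1 to compound 4 (0.27 log units; within the scatter)), so the advantage of compound 2 over compound 1 does not carry over to compound 4, and among these compounds only the vinyl group of compound 2 gives a number beyond the scatter of compound 1 at this place. Nothing available accounts for this reversal.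

The compounds shown do not separate the branching at the chain end from the added carbons, which a straight pent-2-en-1-yl chain at the same place could address. As far as these compounds go, whether the double bond contributes is also open, and a saturated 3-methylbutyl chain or a propyl chain would bear on that, as would an amine or a carboxylic acid at the chain end for a different kind of group.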